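The source may hold more compounds than are shown below. What is called first, only, known or untested is meant among the compounds shown, and "the series" means these compounds.

Compound 1, `O=C(Nc1ccc(Oc2ccnc3[nH]ccc23)cc1)c1ccc(-c2ccc(F)cc2F)cn1`, in a functional assay on MCF7 cells (Homo sapiens) for cytotoxicity, read by MTT assay, with a stated time of 72 h; a higher number here means a weaker inhibitor, a lower number a stronger inhibitor: > 10000 nM, which is a limit of the assay and not a number.
Compound 2, `CCc1ccc(-c2ccc(C(=O)Nc3ccc(Oc4ccnc5[nH]ccc45)cc3)nc2)cc1`, in this assay: > 10000 nM, also only a limit.
Compound 3, `Cc1ccc(-c2ccnc(C(=O)Nc3ccc(Oc4ccnc5[nH]ccc45)cc3)c2)cc1`, in this assay: > 10000 nM, again only a limit.

The three measured compounds share one core and differ only in the aromatic group carried on it. Exchanging 2,4-difluorophenyl for 4-ethylphenyl gave a step that the two limits leave unreadable from compound 1 to compound 2; its size cannot be read because the limit of > 10000 nM in this assay, at which 3 of the 3 values shown sit, holds for every value seen so far. Compound 3 therefore stands nowhere in particular on the numbers shown: its value is a limit, as are the two others, so nothing separates it from compound 1 or compound 2.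

Compound 4, `Cc1cccc(-c2ccnc(C(=O)Nc3ccc(Oc4ccnc5[nH]ccc45)cc3)c2)c1`, is the next step and differs from compound 3 by 3-methylphenyl in place of 4-methylphenyl on an aromatic carbon. Among the measured compounds shown here, no measured step covers the move of a methyl from one position of the phenyl ring to another, and the single step that exists is unreadable. For the measured compounds named here, with every value so far at the limit, the expectation for compound 4 in this assay is that it will again return only a limit, estimated at 20000 nM, within a range of 8000 nM to 60000 nM. The step from compound 3 to compound 4 is thus expected to be a step that the limit leaves unreadable from compound 3 to compound 4, that is, none beyond the scatter.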

Compound 4, half-maximal inhibitory concentration: 7470 nM
Compound 4: middle estimate off by 2.7-fold (0.43 log units), on the high side; measured number outside the range, below it.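

Compound 4 gives 7470 nM in this assay, the first value among the compounds shown that is a number and not a limit, so the position of one methyl on this phenyl ring can decide whether a number can be read at all. Taking 3-methylphenyl in place of 4-methylphenyl, on the carbon opposite the ring nitrogen, gives an at least 1.3-fold lower number from compound 3 to compound 4 (0.12 log units; that floor lies within the scatter), so the data guarantee only a small difference, and the real one may be larger. No true size can be given for this step, and the step from compound 1 to compound 2 cannot be read either, because only limits stand on those sides: the limit of > 10000 nM in this assay, at which 3 of the 4 values shown sit.

From the compounds shown here alone, it remains open whether a different group at the same place on the phenyl ring, such as a methoxy group, a chlorine atom or an amine, would move the number clearly beyond the scatter. Going by these compounds, it also remains open whether a longer chain such as ethyl or propyl would keep a readable number in this assay when it is set on the phenyl ring as in 3-methylphenyl.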